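Opening the cyclopropane acid of compound 1

This account rests on a few compounds, and the source may have more. Where it says the series, first, only, none or still open, it means among the compounds named here.

Compound 1 `Cc1cc([C@@H]2C[C@H]2C(=O)O)ccc1-c1noc(-c2ccc(OC(C)C)c(C(F)(F)F)c2)n1` carries a 2-carboxycyclopropyl group on an aromatic carbon of the shared core. In a functional assay on CHO cells for displacement of a labelled ligand from sphingosine 1-phosphate receptor 5 (Homo sapiens), read by GTPgammaS binding (a lower number here means that less compound is needed, a higher number that more compound is needed for the effect), compound 1 gives 5.1 nM, the lowest of the two single numbers available. Compound 2 `Cc1cc([C@H]2C[C@H]2C(=O)O)ccc1-c1noc(-c2ccc(OC(C)C)c(C#N)c2)n1` gives 37.7 nM in this assay, a gap beyond the usual scatter. Compound 3 `Cc1cc([C@@H]2C[C@H]2C(=O)O)ccc1-c1noc(-c2ccc(OC(C)C)c(C#N)c2)n1` gives 88.4 nM; 5.2 nM; 13.6 nM (3 entries) in this assay; because the several entries of compound 3 in this assay, 88.4 nM; 5.2 nM; 13.6 nM (3 entries) spread so widely, compound 3 offers no single number, even though the fact that compounds 2 and 3 differ only in the configuration as drawn makes it the closest relative of compound 2.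

Compound 4 `Cc1cc(CC(C)C(=O)O)ccc1-c1noc(-c2ccc(OC(C)C)c(C(F)(F)F)c2)n1` differs from compound 1 in one place: 2-carboxypropyl in place of 2-carboxycyclopropyl on an aromatic carbon. Among the measured compounds shown here, no measured pair shows this ring-opening. The expected step of a 4.9-fold higher number from compound 1 to compound 4 (0.69 log units; beyond the scatter) is a move toward a higher number, beyond the scatter. Compound 4 is estimated at 25 nM, within 5 nM to 120 nM.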

Compound 4, half-maximal effective concentration: 9.9 nM
Compound 4: the middle estimate sits 2.5-fold (0.40 log units) above what was measured; the measured number falls inside the stated range.
By their numbers in this assay, from the lowest: compounds 1 and 4 (each within the scatter of the next); then compound 2.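

The ring-opening gives a 1.9-fold higher number from compound 1 to compound 4 (0.29 log units; within the scatter) in this assay. At this position, then, the 2-carboxypropyl and 2-carboxycyclopropyl groups cannot be told apart, so with the trifluoromethyl group in place, neither the three-membered ring nor its 2 defined stereocentres is needed for a low number. Nothing shown explains this result.

On these data alone, whether a longer chain ending in the carboxylic acid, or an amine in its place, would be tolerated here remains open. So does whether 2-carboxypropyl matches the ring in compounds carrying the nitrile.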